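Swapping Methoxy for Methyl on the Amine Side Chain

This account rests on a few compounds, and the source may have more. Where it says the series, first, only, none or still open, it means among the compounds named here.

Three compounds have been measured in an in vitro assay on 293-EBNA cells for binding affinity to corticotropin-releasing factor receptor 1 (Homo sapiens); a lower number here means a stronger inhibitor, a higher number a weaker inhibitor:

Compound 1, `CCC(COC)Nc1nc(C)nc2c1nnn2-c1c(C)cc(C)cc1C`, gives 59.4 nM.
Compound 2, `CCC(CC)Nc1nc(C)nc2c1nnn2-c1c(C)cc(C)cc1C`, gives 5.7 nM.
Compound 3, `COCCCNc1nc(C)nc2c1nnn2-c1ccc(C(C)C)cc1Br`, gives 291 nM.

Compound 1 and compound 2 share one core and differ in a single place: methyl in place of methoxy on a saturated chain carbon, two bonds along the chain from a nitrogen on an aromatic ring. That single exchange produced a 10-fold lower number from compound 1 to compound 2 (1.02 log units; beyond the scatter). Compound 3 is built on a different core; the difference between the two cores is not broken down here, and compound 3 shows the highest number of the three.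

Compound 4, `CCCCNc1nc(C)nc2c1nnn2-c1ccc(C(C)C)cc1Br`, has not yet been measured. It differs from compound 3 by methyl in place of methoxy on a saturated chain carbon, three bonds along the chain from a nitrogen on an aromatic ring. For the measured compounds named here, this is the same kind of change as the one between compound 1 and compound 2, but not the same: the earlier methoxy sat on a saturated chain carbon two bonds along the chain from a nitrogen on an aromatic ring, whereas here it sits three bonds along the chain from a nitrogen on an aromatic ring, and the cores differ as well.

Because a 10-fold lower number from compound 1 to compound 2 (1.02 log units; beyond the scatter) was made at a different place on a different core, only part of that gain is expected to carry over, so the expected step is a 3.2-fold lower number from compound 3 to compound 4 (0.51 log units; beyond the scatter). Compound 4 is therefore estimated at 90 nM, with the expected range running from 30 nM to 250 nM.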

Compound 4, inhibition constant: 69.6 nM
For compound 4 the middle estimate is 1.3-fold (0.11 log units) above the measured one; low and high end bracket the measured number.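

Putting methyl in place of methoxy worked in the same direction again in this assay, giving a 4.2-fold lower number from compound 3 to compound 4 (0.62 log units; beyond the scatter) on a second core. The new step can be set beside the earlier one, and the two sizes cannot be told apart: the same change on two cores in this assay, a 10-fold lower number (1.02 log units; beyond the scatter) from compound 1 to compound 2 and a 4.2-fold lower number (0.62 log units; beyond the scatter) from compound 3 to compound 4, 2.5-fold (0.40 log units) apart, within the scatter of two such steps. For the compounds shown here, this supports carrying the exchange from one core to the other in this small series, but it rests on only two pairs, so it does not show that the gain has a fixed size, that it would appear on any further core, or why the number falls at all.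

The compounds shown leave open how a hydroxyl or an amine would compare with methoxy and methyl on the same chain carbon, and whether a chain longer than butyl would lower the number further. They also leave open the separate roles of place and core, which could be told apart by making the exchange three bonds along the chain on the core of compound 1 and two bonds along the chain on the core of compound 3.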